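Swapping Acetyl for Methoxy on a Kinase Binder

The compounds below may be only part of what the source reports. "The series", "measured", "known", "first", "only" and "open" are said of these compounds alone.

Compound 1 `CC(=O)c1cccc(NC(=O)Nc2cc(Oc3ccc4nc(NC(=O)C5CC5)sc4c3)ccc2F)c1` was tested in an assay for binding affinity to receptor-interacting serine/threonine-protein kinase 3 (Homo sapiens), read by KINOMEscan and polymerase chain reaction, with a stated time of 1 h (on this read-out higher numbers stand for weaker binding and lower numbers for tighter binding), where compound 1 gives 53 nM. For the measured compounds named here, that is the only number in this set, so compound 1 stands alone as the reference point. A second compound, compound 2 `O=C(Nc1nc2ccc(Oc3ccc(F)c(NS(=O)(=O)c4cccc(C(F)(F)F)c4)c3)cc2s1)C1CC1`, belongs to the same series, but in this assay compound 2 gives "not determined" (no result reported), so it adds nothing to the comparison.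

The next step leads to compound 3 `COc1cccc(NC(=O)Nc2cc(Oc3ccc4nc(NC(=O)C5CC5)sc4c3)ccc2F)c1`. The change from compound 1 to compound 3 is methoxy in place of acetyl on an aromatic carbon. Both groups sit on the same aromatic carbon of the six-membered ring of carbon only, and each carries one hydrogen-bond acceptor, so the shared core and the rest of the molecule are untouched.

Going by the values given here, with no measured pair to show how this exchange plays out, the step in this assay is expected to be modest, an estimated 2.3-fold higher number from compound 1 to compound 3 (0.35 log units; beyond the scatter) towards weaker binding, close to the usual scatter. Compound 3 is therefore expected to give about 120 nM, with a likely range from 40 nM to 400 nM.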

Compound 3, dissociation constant: 69 nM
Compound 3: middle estimate off by 1.7-fold (0.24 log units), on the high side, within the range that was stated.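

In this assay, putting methoxy in place of acetyl on this aromatic carbon gives a 1.3-fold higher number from compound 1 to compound 3 (0.11 log units; within the scatter), so the two compounds cannot be told apart on this read-out. For the compounds shown here, this is the first measured step at this position, and it shows that binding here does not depend on keeping the acetyl group: the 3-methoxyphenyl version holds up as well as the 3-acetylphenyl version, even though the double bond outside the aromatic ring is gone and the group is smaller. No measurement in hand bears on why the two groups behave alike, so the result describes what happens and offers no explanation.

As far as these compounds go, a single exchange between two similar-sized groups that each carry a hydrogen-bond acceptor marks only a small part of what this position might tolerate, so it is still open how an amine, a carboxylic acid or a longer chain such as butoxy would fare on the same carbon. From the compounds shown here alone, it is also open whether a plain hydrogen there would keep binding in this assay, which would show whether either group contributes at all.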